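This account rests on a few compounds, and the source may have more. Where it says the series, first, only, none or still open, it means among the compounds named here.

Compound 1 `COc1ccc(Cn2c(CCc3ccccc3)nnc2[C@H](NC(=O)C(C)(C)N)c2c[nH]c3ccccc23)cc1`: 11 nM
Compound 2 `CCc1ccc(-n2c(CCc3c[nH]c4ccccc34)nnc2[C@H](NC(=O)c2ccccn2)c2c[nH]c3ccccc23)cc1`: 49 nM

Both compounds were run in an in vitro assay on LLC-PK1 cells for displacement of a labelled ligand from growth hormone secretagogue receptor type 1 (Homo sapiens); on this read-out lower numbers stand for stronger inhibition and higher numbers for weaker inhibition. Compound 1 gives 11 nM and compound 2 gives 49 nM; compound 2 therefore stands with the higher of the two numbers, and its gap to compound 1 lies beyond the scatter. Among the compounds with values here, the two structures differ in several places at once, so no single step between them can be traced, and their values show only where each stands.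

Compound 3 `O=C(N[C@H](c1c[nH]c2ccccc12)c1nnc(CCc2c[nH]c3ccccc23)n1-c1ccccc1)c1ccccn1` has not yet been measured. It differs from compound 2 in one place: hydrogen in place of ethyl on an aromatic carbon, para to a large group on a six-membered aromatic ring of carbon only; cut one bond further out, the difference reads 4-ethylphenyl to phenyl. Within the data shown here, no step of this kind between measured compounds is available, so the expectation rests on the change being a small one in a peripheral part of the molecule. The expected step is a 1.4-fold higher number from compound 2 to compound 3 (0.15 log units; within the scatter), a slight rise that may well stay within the scatter. Compound 3 is accordingly estimated at 70 nM, with a range from 25 nM to 200 nM.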

Compound 3, half-maximal inhibitory concentration: 160 nM
Compound 3: the middle estimate sits 2.3-fold (0.36 log units) below what was measured; the measured number falls inside the stated range.
By their numbers in this assay, from the lowest: compound 1; then compound 2; then compound 3.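

In this assay, within the data shown here, the change from 4-ethylphenyl to phenyl gives a 3.3-fold higher number from compound 2 to compound 3 (0.51 log units; beyond the scatter), the first step that can be traced to a single place. It shows that this position, on an aromatic carbon para to a large group, is not indifferent to what it carries: ethyl, with its 2 carbons, goes with the lower number, and plain hydrogen goes with the higher one, and the gap lies beyond the usual scatter. Among these compounds, nothing available explains why the number rises when ethyl leaves, and the single step stands as an observation about this one pair on this one read-out.

The compounds shown leave open whether the number keeps falling with a longer chain such as propyl or butyl at this position, or whether a methoxy group, a chlorine atom or an amine there would serve as ethyl does. They also leave open whether ethyl in place of hydrogen at this position would carry the same weight with a different amide on the rest of the molecule.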